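Fluoro replacing dimethylamino on the aniline ring

The source may report more compounds than this note shows. Statements on the series, on what has been measured and on what is new or still open speak of the compounds shown alone.

Measured compounds:
compound 1, `COc1cccc(Nc2nccc(-c3ccncc3)n2)c1`, 400 nM
compound 2, `NS(=O)(=O)c1cccc(Nc2nccc(-c3ccncc3)n2)c1`, 500 nM
compound 3, `CN(C)c1cccc(Nc2nccc(-c3ccncc3)n2)c1`, 3700 nM

Three analogues sharing one core were tested in a functional assay for inhibition, with Homo sapiens as the target; on this read-out higher numbers stand for weaker inhibition and lower numbers for stronger inhibition. Compound 3 stands at the highest number of the three: the step of a 9.3-fold higher number from compound 1 to compound 3 (0.97 log units; beyond the scatter) and the step of a 7.4-fold higher number from compound 2 to compound 3 (0.87 log units; beyond the scatter) both lie beyond the scatter, while compound 1 and compound 2 sit within the scatter of each other, a 1.3-fold higher number from compound 1 to compound 2 (0.10 log units; within the scatter).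

Compound 4, `Fc1cccc(Nc2nccc(-c3ccncc3)n2)c1`, is not yet measured. It differs from compound 3 by one change: fluoro in place of dimethylamino on an aromatic carbon. Within the data shown here, no measured step introduces fluoro, so the expectation for compound 4 rests on the two steps that remove dimethylamino from this position in the other direction. Both show that the dimethylamino analogue gives the weakest number, and the two other substituents tried at this position land close together. If fluoro behaves more like those than like dimethylamino, compound 4 is expected to give a lower number than compound 3, estimated at a 5.3-fold lower number from compound 3 to compound 4 (0.72 log units; beyond the scatter) in this assay. Among the measured compounds shown here, the estimate for compound 4 is therefore 700 nM, with a range from 250 nM to 2500 nM, the width reflecting that fluoro has no direct precedent here.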

Compound 4, half-maximal inhibitory concentration: 700 nM
For compound 4 middle estimate and measured number coincide at the digits printed; the range from low to high includes it.
By their numbers in this assay, from the lowest: compounds 1, 2 and 4 (each within the scatter of the next); then compound 3.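

In this assay, fluoro in place of dimethylamino gives a 5.3-fold lower number from compound 3 to compound 4 (0.72 log units; beyond the scatter), a step beyond the scatter, while the comparisons with the other two analogues, a 1.4-fold higher number from compound 2 to compound 4 (0.15 log units; within the scatter) and a 1.8-fold higher number from compound 1 to compound 4 (0.24 log units; within the scatter), both stay within it. Two groups agreeing at this aromatic carbon could have been a chance match, but a third, the single-atom fluoro, now falls in with methoxy and sulfamoyl, so among these four compounds it is compound 3 that goes against the shared level and the other three that define it. Nothing available here explains why dimethylamino alone stands apart.

On these data alone, it remains open whether that separation belongs to dimethylamino specifically or extends to related nitrogen groups such as a primary amine or a methylamino group. How a carboxylic acid, a longer alkyl chain or a plain hydrogen at this same carbon would compare with compound 1, compound 2 and compound 4 is also unresolved.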